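This account rests on a few compounds, and the source may have more. Where it says the series, first, only, none or still open, it means among the compounds named here.

Within the data shown here, compound 1 `COC(=O)[C@@H](CC(C)C)NC(=O)Cn1cc(C2=C(c3c[nH]c4ccccc34)C(=O)N(C)C2=O)c2ccccc21` is the only compound of this set with a measured number in a functional assay on A2780 cells (Homo sapiens) for cytotoxicity, read by MTT assay, with a stated time of 24 h; a lower number here means a stronger inhibitor, a higher number a weaker inhibitor: in that assay compound 1 gives 38500 nM. Compound 2 `CC[C@H](C)[C@@H](NC(=O)Cn1cc(C2=C(c3c[nH]c4ccccc34)C(=O)N(C)C2=O)c2ccccc21)C(=O)OC` returns only a limit in this assay; compound 2 gives > 100000 nM, which is a limit and not a number. Among the measured compounds shown here, that step, an at least 2.5-fold higher number from compound 1 to compound 2 (0.41 log units; beyond the scatter), is the one measured change at the saturated chain carbon bound to an amide-type nitrogen and a carbonyl carbon.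

Compound 3 `COC(=O)C[C@@H](NC(=O)Cn1cc(C2=C(c3c[nH]c4ccccc34)C(=O)N(C)C2=O)c2ccccc21)C(=O)OC` has not yet been measured in this assay. It differs from compound 1 by methoxycarbonyl in place of isopropyl on a saturated chain carbon, two bonds along the chain from an amide-type nitrogen and a carbonyl carbon. For the measured compounds named here, the only measured step that bears on it, an at least 2.5-fold higher number from compound 1 to compound 2 (0.41 log units; beyond the scatter), went toward weaker inhibition, and one of the two values sits at the limit of > 100000 nM in this assay, at which 1 of the 2 values shown sits. Compound 3 is therefore expected to show a 1.8-fold higher number from compound 1 to compound 3 (0.26 log units; within the scatter), with a real chance that only a limit is returned. Compound 3 is expected to give 70000 nM, between 25000 nM and 200000 nM.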

Compound 3, half-maximal inhibitory concentration: 15400 nM
The estimate for compound 3 lay 4.5-fold (0.66 log units) above the measured number, outside the stated range (below it).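

In this assay, this position proves able to move the number in both directions: methoxycarbonyl in place of isopropyl, on a saturated chain carbon, two bonds along the chain from an amide-type nitrogen and a carbonyl carbon, gives a 2.5-fold lower number from compound 1 to compound 3 (0.40 log units; beyond the scatter), the opposite direction to the earlier step from isobutyl to sec-butyl. Measured against the sec-butyl compound, (methoxycarbonyl)methyl gives an at least 6.4-fold lower number from compound 2 to compound 3 (0.81 log units; beyond the scatter), which leaves compound 3 with the lowest number of the three. For compound 2 the value is a limit and not a number, so that second step has only a lower bound: the limit of > 100000 nM in this assay, at which 1 of the 3 values shown sits.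

The compounds shown leave open whether the gain belongs to the ester itself or to any group of this size at this place. A carboxylic acid, a primary amide or a longer chain ending in the ester would separate these readings.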